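Compound 3: a 4-carbamoylcyclohexyl group enters

A few compounds are considered here, and "the series" means these few. Any claim that something is new, unique, unknown or untested is made for them only; others in the source may bear on it.

- compound 1 (`N#Cc1cnc(NCc2cnccc2C(F)(F)F)cc1N[C@H]1CC[C@H](O)CC1`) gives 25%
- compound 2 (`N#Cc1cnc(NCc2cnccc2C(F)(F)F)cc1NC[C@H]1CC[C@@H](O)CC1`) gives 18%

Both numbers come from an ADME assay on S9 fraction from liver (Rattus norvegicus) for metabolic stability, with a stated time of 1 h (on this read-out lower numbers stand for a less stable compound and higher numbers for a more stable compound), and lie within the scatter of each other. Compound 2 stands at 18% on this read-out, and no order can be drawn between it and compound 1.

The next compound is compound 3 (`N#Cc1cnc(NCc2cnccc2C(F)(F)F)cc1N[C@H]1CC[C@@H](C(N)=O)CC1`), so far unmeasured. The change is 4-carbamoylcyclohexyl in place of (4-hydroxycyclohexyl)methyl on a nitrogen on an aromatic ring and reads in words as 4-carbamoylcyclohexyl in place of (4-hydroxycyclohexyl)methyl on a nitrogen on an aromatic ring.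

Going by the values given here, one measured step bears on it, at the same place (a number 7 percentage points lower from compound 1 to compound 2 (within the scatter)), where (4-hydroxycyclohexyl)methyl took the place of 4-hydroxycyclohexyl. Among the compounds with values here, that step stayed within the scatter, yet no measured compound carries the 4-carbamoylcyclohexyl group, so the evidence is thin and the range must stay wide. A step beyond the scatter is therefore not expected, and the estimated change is a number 7 percentage points higher from compound 2 to compound 3 (within the scatter) in this assay with no firm direction. For compound 3 the estimated value is 25% with an expected range from 10% to 50% on this read-out.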

Compound 3, percent of the compound remaining: 30%
Compound 3: the middle estimate sits 5 percentage points below what was measured, within the range that was stated.
By their numbers in this assay, from the lowest: compounds 2, 1 and 3 (each within the scatter of the next, the first and the last beyond it).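

In this assay, going by these compounds alone, the 4-carbamoylcyclohexyl group gives the first step at this nitrogen on an aromatic ring to pass the scatter, with a reading of a number 12 percentage points higher from compound 2 to compound 3 (beyond the scatter) when it replaces (4-hydroxycyclohexyl)methyl. That step does not extend to the other alcohol-bearing group: in place of 4-hydroxycyclohexyl, the same group gives a number 5 percentage points higher from compound 1 to compound 3 (within the scatter) and no order can be drawn, so the compounds shown support a difference from compound 2 only. No information is available that explains either step.

The step from compound 2 to compound 3 also changes two things at once, the methyl link between the nitrogen and the ring and the group carried on the ring, and the compounds shown leave open how much each part contributes. A (4-carbamoylcyclohexyl)methyl group would separate those two parts, while a carboxylic acid or an amine in place of the carbamoyl group would show whether stability on this read-out moves at all with what the cyclohexyl ring carries.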